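Swapping 4-methoxy-3-methylphenyl for anilino

The source may report more compounds than this note shows. Statements on the series, on what has been measured and on what is new or still open speak of the compounds shown alone.

In a functional assay on Jurkat cells (Homo sapiens) for antiproliferative activity, read by MTT assay, with a stated time of 72 h (a lower number here means a stronger inhibitor, a higher number a weaker inhibitor), compound 1 (`COc1cc(C(=O)c2sc3ccccc3c2-c2ccccc2)cc(OC)c1OC`) gives 1500 nM. Compound 2 (`COc1ccc(-c2c(C(=O)c3cc(OC)c(OC)c(OC)c3)sc3ccccc23)cc1C`) gives > 10000 nM, which is a limit of the assay and not a number. Compound 3 (`COc1cc(C(=O)c2sc3ccccc3c2Nc2ccccc2)cc(OC)c1OC`) is the next to be tested, with anilino in place of 4-methoxy-3-methylphenyl on an aromatic carbon. Going by the values given here, one measured step bears on this change: an at least 6.6-fold higher number from compound 1 to compound 2 (0.82 log units; beyond the scatter), with 4-methoxy-3-methylphenyl in place of phenyl on an aromatic carbon. Anilino, like the phenyl of compound 1 at 1500 nM, brings one six-membered aromatic ring of carbon only, so a lower number is expected in this assay, beyond the scatter. Among the compounds with values here, no measured step shows what anilino itself does, so the expectation stays wide. The expected step is an at least 4.0-fold lower number from compound 2 to compound 3 (0.60 log units; beyond the scatter). Compound 3 is estimated at 2500 nM, with an expected range from 500 nM to 10000 nM.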

Compound 3, half-maximal inhibitory concentration: 1600 nM
Compound 3: the middle estimate sits 1.6-fold (0.19 log units) above what was measured; low and high end bracket the measured number.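

In this assay, putting anilino in place of 4-methoxy-3-methylphenyl gives an at least 6.2-fold lower number from compound 2 to compound 3 (0.79 log units; beyond the scatter) and shows that this position of the shared core can carry a ring attached through nitrogen. Set against phenyl, the same group gives a 1.1-fold higher number from compound 1 to compound 3 (0.03 log units; within the scatter) and cannot be told apart from it here, although anilino brings a hydrogen-bond donor that 4-methoxy-3-methylphenyl does not. Compound 2 gives > 10000 nM as a limit of the assay and not a number, so the step from it is a bound on size only: the limit of > 10000 nM in this assay, at which 1 of the 3 values shown sits.

The compounds shown leave open whether the methoxy or the methyl of 4-methoxy-3-methylphenyl carries the loss seen against phenyl. They also leave open how a plain amine at this position, or a methoxy on the ring of anilino, would compare.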